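The source may hold more compounds than are shown below. What is called first, only, known or untested is meant among the compounds shown, and "the series" means these compounds.

Working notes on the shared core of compound 1 `CCCNc1nc(C)c(-c2nc3ccccc3s2)c(N[C@@H]2C[C@H](CO)[C@@H](O)[C@H]2O)n1` in an ADME assay on cells (Homo sapiens) for cytotoxicity, read by polymerase chain reaction, with a stated time of 3 days; a higher number here means that more compound is tolerated, a lower number that less compound is tolerated. Compound 1 gives > 25000 nM, which is a limit of the assay and not a number. Compound 2 `CCOCCNc1nc(C)c(-c2nc3ccccc3s2)c(N[C@@H]2C[C@H](CO)[C@@H](O)[C@H]2O)n1` gives 18000 nM. Compound 3 `Cc1nc(Nc2ncco2)nc(N[C@@H]2C[C@H](CO)[C@@H](O)[C@H]2O)c1-c1nc2ccccc2s1` gives > 25000 nM, again a limit of the assay. Compound 3 therefore stands at the upper edge of what this assay reports, as described by the limit of > 25000 nM in this assay, at which 2 of the 3 values shown sit. The step of an at least 1.3-fold lower number from compound 1 to compound 2 (0.14 log units; that floor lies within the scatter) lies within the scatter, as does the step of an at least 1.3-fold higher number from compound 2 to compound 3 (0.14 log units; that floor lies within the scatter), and the step that the two limits leave unreadable from compound 1 to compound 3 is unreadable, both of its ends being limits.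

Compound 4 `Cc1nc(NCc2ccccc2)nc(N[C@@H]2C[C@H](CO)[C@@H](O)[C@H]2O)c1-c1nc2ccccc2s1` differs from compound 3 by benzyl in place of 1,3-oxazol-2-yl on a nitrogen on an aromatic ring. The measured steps that touch the same nitrogen, a step that the two limits leave unreadable from compound 1 to compound 3 and an at least 1.3-fold higher number from compound 2 to compound 3 (0.14 log units; that floor lies within the scatter), show nothing beyond the scatter, so no shift beyond the scatter is expected in this assay. Compound 4 is estimated at 25000 nM, with a range from 10000 nM to 60000 nM. The expected step of a number no higher from compound 3 to compound 4 (the limit leaves the size open) is thus negligible, and a limit rather than a number is likely to be reported again.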

Compound 4, half-maximal cytotoxic concentration: 9000 nM
Estimate against measurement, compound 4: 2.8-fold (0.44 log units) above; measured number below the stated range.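

In this assay, among these compounds, the group on this nitrogen moves the number beyond the scatter for the first time, with benzyl compared against 1,3-oxazol-2-yl (an at least 2.7-fold lower number from compound 3 to compound 4 (0.44 log units; beyond the scatter)) and against propyl (an at least 2.7-fold lower number from compound 1 to compound 4 (0.44 log units; beyond the scatter)). The comparison with 2-ethoxyethyl gives no such separation (a 2.0-fold lower number from compound 2 to compound 4 (0.30 log units; within the scatter)), so the change is not seen against all three groups. Going by these compounds, both steps beyond the scatter are floors, and their full size stays open because compound 1 and compound 3 each sit at a limit of the assay: the limit of > 25000 nM in this assay, at which 2 of the 4 values shown sit.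

On these data alone, it remains open whether the lower number follows the carbon-only aromatic ring or the chain carbon that carries it. Pyridin-2-ylmethyl, a longer chain ending in phenyl, or a chain ending in a carboxylic acid on this nitrogen would bear on that.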